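Aryl urea series: bromo for heptyl in whole-organism readout

The compounds below may be only part of what the source reports. "The series", "measured", "known", "first", "only" and "open" are said of these compounds alone.

Compound 1 `C[C@@H](NC(=O)Nc1ccc(C(C)(C)C)cc1)c1ccccc1` gives 88% in an ADME assay on the whole organism with Oryza sativa as the target, tested at 1 uM; a higher number here means a weaker effect of the compound at the concentration tested, a lower number a stronger effect. Compound 2 `CCCCCc1ccc(NC(=O)N[C@H](C)c2ccccc2)cc1` gives 101% and compound 3 `CCCCCCCc1ccc(NC(=O)N[C@H](C)c2ccccc2)cc1` gives 100%. Compound 3 stands together with compound 2, the two values lying within the scatter of each other, as a number 1 percentage points lower from compound 2 to compound 3 (within the scatter) shows; both sit apart from compound 1, with a number 12 percentage points higher from compound 1 to compound 3 (beyond the scatter) and a number 13 percentage points higher from compound 1 to compound 2 (beyond the scatter) both beyond the scatter, so that compound 1 is the only one of the three with a stronger effect at the concentration tested.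

Compound 4 `C[C@@H](NC(=O)Nc1ccc(Br)cc1)c1ccccc1` differs from compound 3 in one place: bromo in place of heptyl on an aromatic carbon. Going by the values given here, no measured step exchanges an alkyl chain for a halogen, so none bears directly on this change. Among the compounds with values here, the only steps at the same position, a number 13 percentage points higher from compound 1 to compound 2 (beyond the scatter) and a number 12 percentage points higher from compound 1 to compound 3 (beyond the scatter), were modest, and the smaller group there went with the lower number. A lower number is therefore expected for compound 4, of modest size, estimated as a number 10 percentage points lower from compound 3 to compound 4 (within the scatter). Compound 4 is estimated at 90%, between 75% and 105%.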

Compound 4, a percentage reported as activity, at one concentration (the size of the read-out at that concentration, not a potency): 95%
Estimate against measurement, compound 4: 5 percentage points below; low and high end bracket the measured number.
By their numbers in this assay, from the lowest: compounds 1, 4, 3 and 2 (each within the scatter of the next, the first and the last beyond it).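

In this assay, the exchange of heptyl for bromo gives a number 5 percentage points lower from compound 3 to compound 4 (within the scatter) and the exchange of pentyl for bromo gives a number 6 percentage points lower from compound 2 to compound 4 (within the scatter) on the same aromatic carbon. The exchange of tert-butyl for bromo gives a number 7 percentage points higher from compound 1 to compound 4 (within the scatter) in the same place, so bromo, with its single heavy atom, cannot be told apart from any of the three alkyl groups, although compound 1 stands apart from compound 2 and compound 3. Nothing at hand explains these numbers.

From the compounds shown here alone, whether an amine or a carboxylic acid on this carbon would give a number beyond the scatter from compound 4 stays open. Also open, going by these compounds, is whether chloro would read like bromo here, and whether a stronger effect can be found at this position at all.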